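Replacing the Carboxyphenyl Arm of an Oxazole Ketone with Tetrazole

The source may hold more compounds than are shown below. What is called first, only, known or untested is meant among the compounds shown, and "the series" means these compounds.

Compound 1 `NS(=O)(=O)c1ccccc1-c1cnc(C(=O)CCCCCCc2ccccc2)o1`: 1500 nM
Compound 2 `O=C(O)c1ccc(-c2cnc(C(=O)CCCCCCc3ccccc3)o2)cc1`: 60 nM

In an assay (Rattus norvegicus) for inhibition of Fatty-acid amide hydrolase 1 (Homo sapiens) (a higher number here means a weaker inhibitor, a lower number a stronger inhibitor), compound 2 has the lowest number of the two, and compound 1 sits beyond the scatter above it. Compound 3 `O=C(CCCCCCc1ccccc1)c1ncc(-c2nnn[nH]2)o1` has not been measured. The change from compound 2 to compound 3 is 1H-tetrazol-5-yl in place of 4-carboxyphenyl on an aromatic carbon. Among the measured compounds shown here, no measured pair covers this change, so the direction rests on expectation only. Compound 2 gives 60 nM in this assay, and a moderate step towards a higher number, beyond the scatter, is expected as a 5.0-fold higher number from compound 2 to compound 3 (0.70 log units; beyond the scatter). For compound 3 the estimate is 300 nM, within 60 nM to 2000 nM.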

Compound 3, inhibition constant: 63 nM
Compound 3: middle estimate off by 4.8-fold (0.68 log units), on the high side, and the stated range covers the measured number.
By their numbers in this assay, from the lowest: compounds 2 and 3 (each within the scatter of the next); then compound 1.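

In this assay, 1H-tetrazol-5-yl in place of 4-carboxyphenyl gives a 1.1-fold higher number from compound 2 to compound 3 (0.02 log units; within the scatter) on this aromatic carbon. This position therefore accepts a group of 5 heavy atoms as well as one of 9, and the six-membered aromatic ring can be lost without a step beyond the scatter. Nothing measured here explains why the two groups match.
Still open, from the compounds shown here alone, is what a carboxylic acid attached directly to this same carbon would give. An amine at this position is equally unexplored by the compounds shown.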